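From 2-chlorophenyl to 4-chlorophenyl: notes on the series

The compounds below may be only part of what the source reports. "The series", "measured", "known", "first", "only" and "open" are said of these compounds alone.

In a functional assay on DLA cells (Mus musculus) for cytotoxicity, read by LDH release, with a stated time of 48 h (on this read-out higher numbers stand for weaker inhibition and lower numbers for stronger inhibition), compound 1 `Cc1ccc(OCC(=O)NNC(=O)c2cc3ccccc3oc2=O)c(C(=O)c2ccccc2Br)c1` gives 10600 nM, compound 2 `Cc1ccc(OCC(=O)NNC(=O)c2cc3ccccc3oc2=O)c(C(=O)c2ccccc2)c1` gives 87000 nM and compound 3 `Cc1ccc(OCC(=O)NNC(=O)c2cc3ccccc3oc2=O)c(C(=O)c2ccccc2Cl)c1` gives 54400 nM. Compound 3 is not separated from compound 2 and stands clear of compound 1 only. Two measured steps end there: a 1.6-fold lower number from compound 2 to compound 3 (0.20 log units; within the scatter), and a 5.1-fold higher number from compound 1 to compound 3 (0.71 log units; beyond the scatter).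

Compound 4 `Cc1ccc(OCC(=O)NNC(=O)c2cc3ccccc3oc2=O)c(C(=O)c2ccc(Cl)cc2)c1` differs from compound 3 as follows: 4-chlorophenyl in place of 2-chlorophenyl on a carbonyl carbon. Going by the values given here, no measured step moves a chloro group. The closest guide is the chloro-for-hydrogen change, a 1.6-fold lower number from compound 2 to compound 3 (0.20 log units; within the scatter), while the bromo comparison, an 8.2-fold higher number from compound 1 to compound 2 (0.91 log units; beyond the scatter), argues for a wide range. No shift beyond the scatter is expected in this assay, the expected change being a 1.2-fold lower number from compound 3 to compound 4 (0.08 log units; within the scatter). Compound 4 is estimated at 45000 nM, with an expected range of 16000 nM to 110000 nM.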

Compound 4, half-maximal inhibitory concentration: 60400 nM
Compound 4: middle estimate off by 1.3-fold (0.13 log units), on the low side; the measured number falls inside the stated range.
By their numbers in this assay, from the lowest: compound 1; then compounds 3, 4 and 2 (each within the scatter of the next).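

Moving the chloro group, 4-chlorophenyl in place of 2-chlorophenyl on the carbonyl carbon, gives no shift beyond the scatter in this assay (a 1.1-fold higher number from compound 3 to compound 4 (0.05 log units; within the scatter)). With the chloro group in this new place the series again stays close to the compound without it (a 1.4-fold lower number from compound 2 to compound 4 (0.16 log units; within the scatter)). Only the 2-bromophenyl compound stands apart (a 5.7-fold higher number from compound 1 to compound 4 (0.76 log units; beyond the scatter)), so among these compounds bromo remains the one change with a readable step.

On these data alone, whether a methoxy group or an amine in place of this chloro would move the number beyond the scatter stays open, as does whether compound 1 owes its separation to bromo itself. Nothing available explains any of these steps.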